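From pyridin-3-yl to phenyl at one chain carbon

The compounds below may be only part of what the source reports. "The series", "measured", "known", "first", "only" and "open" are said of these compounds alone.

Measured in an ADME assay on microsomes from liver (Mus musculus, strain CD-1) for metabolic stability, read by LC-MS, with a stated time of 60 min, tested at 20 uM; on this read-out higher numbers stand for a longer-lived compound and lower numbers for a shorter-lived compound:
Compound 1 `CC(Sc1nc2c(cnn2C)c(=O)n1-c1ccccc1)c1cccc(F)c1`: 0.133 h
Compound 2 `CC(Sc1nc2c(cnn2C)c(=O)n1-c1ccccc1)c1cccnc1`: 0.117 h

Compound 2 at 0.117 h stands within the scatter of compound 1, so the two values cannot be told apart. Compound 3 `CC(Sc1nc2c(cnn2C)c(=O)n1-c1ccccc1)c1ccccc1` carries phenyl in place of pyridin-3-yl on a saturated chain carbon bound to a saturated chain carbon and a sulfur. The change reads phenyl in place of pyridin-3-yl on a saturated chain carbon bound to a saturated chain carbon and a sulfur and nothing else differs. Within the data shown here, only one measured step bears on it, at the same place: a 1.1-fold lower number from compound 1 to compound 2 (0.06 log units; within the scatter) stays within the scatter. No shift beyond the scatter is therefore expected in this assay, and no direction can be claimed with confidence. The expected step is a 1.1-fold higher number from compound 2 to compound 3 (0.05 log units; within the scatter) and it should remain within the scatter. Compound 3 is estimated at 0.13 h with an expected range of 0.065 h to 0.26 h in this read-out.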

Compound 3, half-life: 0.133 h
The estimate for compound 3 lay 1.0-fold (0.01 log units) below the measured number; the measured number falls inside the stated range.
By their numbers in this assay, from the lowest: compounds 2, 1 and 3 (each within the scatter of the next).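

In this assay the exchange of pyridin-3-yl for phenyl gives a 1.1-fold higher number from compound 2 to compound 3 (0.06 log units; within the scatter), so losing the ring nitrogen at this place produces no readable difference in half-life. The third comparison, hydrogen in place of fluoro on an aromatic carbon, gives no change at the digits printed from compound 1 to compound 3 (within the scatter), and so the three aromatic rings on this saturated chain carbon cannot be told apart in this read-out. Nothing available here offers an explanation for this flat result.

Going by these compounds, all three compounds keep a six-membered aromatic ring at this place, so it remains open whether a saturated ring such as cyclohexyl, an amine or a carboxylic acid on this chain carbon would shift the half-life beyond the scatter. On these data alone, the effect of changing the phenyl on the shared core also remains open.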